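The compounds below may be only part of what the source reports. "The series", "measured", "known", "first", "only" and "open" are said of these compounds alone.

Compound 1 `COc1ccc(/C=C/C(=O)c2ccccc2-c2ccc(F)cc2)cc1`: 93 nM
Compound 2 `Cc1ccc(/C=C/C(=O)c2ccccc2-c2ccc(F)cc2)o1`: 12000 nM

Both compounds were measured in a functional assay on HepG2 cells (Homo sapiens) for antiproliferative activity, read by sulforhodamine B assay, with a stated time of 48 h; a lower number here means a stronger inhibitor, a higher number a weaker inhibitor. Compound 2 holds the higher of the two numbers and is the weaker inhibitor here. Going by the values given here, the only measured step is a 130-fold higher number from compound 1 to compound 2 (2.11 log units; beyond the scatter), a large one, and it came with 5-methylfuran-2-yl in place of 4-methoxyphenyl.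

Compound 3 `O=C(/C=C/c1cccs1)c1ccccc1-c1ccc(F)cc1` has not yet been measured. It carries thiophen-2-yl in place of 5-methylfuran-2-yl on a double-bonded chain carbon bound to a double-bonded chain carbon. The measured step bears on this change only indirectly. It shows that the number can move widely with the group at this place, but it replaced a 4-methoxyphenyl group, whereas here one five-membered aromatic ring with 1 hetero atom replaces another. Among the compounds with values here, no measured step covers thiophen-2-yl itself. A far smaller change is therefore expected in this assay, leaning modestly toward lower numbers, with compound 1 at 93 nM showing that such numbers are reachable. The expected step is a 2.4-fold lower number from compound 2 to compound 3 (0.38 log units; beyond the scatter). For compound 3 the estimated value is 5000 nM, with an expected range from 800 nM to 25000 nM.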

Compound 3, half-maximal inhibitory concentration: 6200 nM
Compound 3: middle estimate off by 1.2-fold (0.09 log units), on the low side, and the stated range covers the measured number.
By their numbers in this assay, from the lowest: compound 1; then compounds 3 and 2 (each within the scatter of the next).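

Exchanging one five-membered aromatic ring for another on a double-bonded chain carbon bound to a double-bonded chain carbon gave a 1.9-fold lower number from compound 2 to compound 3 (0.29 log units; within the scatter) in this assay and so leaves thiophen-2-yl and 5-methylfuran-2-yl indistinguishable in this test. Going by these compounds alone, the large loss seen earlier is therefore not tied to 5-methylfuran-2-yl alone, for the second ring shows the same kind of gap with a 67-fold higher number from compound 1 to compound 3 (1.82 log units; beyond the scatter) and compound 1 remains the strongest inhibitor of the three, with no compound here going against this. No measurement at hand accounts for the way the 4-methoxyphenyl group stands apart from both five-membered rings.

The compounds shown leave open whether the gap follows the six-membered ring itself or its methoxy group, a question that plain phenyl or 4-hydroxyphenyl at this place would address. They also cannot separate the methyl group of compound 2 from its ring oxygen, and an unsubstituted furan-2-yl or a 5-methylthiophen-2-yl would be needed to show whether either matters at all.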